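Moving the Nitrile on the Cyanophenyl Group of Compound 1

A few compounds are considered here, and "the series" means these few. Any claim that something is new, unique, unknown or untested is made for them only; others in the source may bear on it.

In a functional assay on HepG2 cells (Homo sapiens) for antiproliferative activity, read by MTT assay, with a stated time of 72 h (on this read-out lower numbers stand for stronger inhibition and higher numbers for weaker inhibition), compound 1 (`COc1cc2c(Nc3cccc(C#N)c3)ncnc2cc1OCCCN1CCC(C)CC1`) gives 18200 nM, compound 2 (`COc1cc2c(Nc3cccc(C#N)c3)ncnc2cc1OCCCN1CCN(C)CC1`) gives 18300 nM, and compound 3 (`CCN1CCN(CCCOc2cc3ncnc(Nc4cccc(C#N)c4)c3cc2OC)CC1`) gives 13700 nM. These three values lie within the scatter of one another, so compound 1 has no meaningful rank among them.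

Compound 4 (`COc1cc2c(Nc3ccccc3C#N)ncnc2cc1OCCCN1CCC(C)CC1`) differs from compound 1 in one place: 2-cyanophenyl in place of 3-cyanophenyl on a nitrogen on an aromatic ring. It carries 2-cyanophenyl in place of 3-cyanophenyl on a nitrogen on an aromatic ring.

The measured steps changed a different part of the molecule, replacing 4-methylpiperidin-1-yl on the saturated chain. They are a 1.0-fold higher number from compound 1 to compound 2 (0.00 log units; within the scatter) and a 1.3-fold lower number from compound 1 to compound 3 (0.12 log units; within the scatter), and the related 1.3-fold lower number from compound 2 to compound 3 (0.13 log units; within the scatter) is similarly small. None of them tests the cyanophenyl group, so they bear on this change only indirectly, and the data offer no firm direction.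

The expected step is modest, with the estimate being a 1.2-fold higher number from compound 1 to compound 4 (0.08 log units; within the scatter). For compound 4, the estimated value is 22000 nM, with an expected range from 8000 nM to 60000 nM.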

Compound 4, half-maximal inhibitory concentration: 4030 nM
For compound 4 the middle estimate is 5.5-fold (0.74 log units) above the measured one; measured number outside the range, below it.
By their numbers in this assay, from the lowest: compound 4; then compounds 3, 1 and 2 (each within the scatter of the next).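

Moving the nitrile is the first change here that registers clearly in this assay: the step to 2-cyanophenyl on the nitrogen gives a 4.5-fold lower number from compound 1 to compound 4 (0.65 log units; beyond the scatter) and carries compound 4 beyond the scatter. The groups that leave and enter have the same atoms and the same counts, so only the way they are joined separates the two compounds, whereas the exchanges on the saturated chain among compounds 1, 2 and 3 stayed within the scatter. Nothing at hand gives a reason for this shift.

The compounds shown leave open whether the nitrile itself matters at this place, or whether a plain phenyl or a 2-chlorophenyl group would give a similar number. They also leave open whether 2-cyanophenyl would give a similar step alongside the 4-methylpiperazin-1-yl of compound 2 or the 4-ethylpiperazin-1-yl of compound 3.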